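This account rests on a few compounds, and the source may have more. Where it says the series, first, only, none or still open, it means among the compounds named here.

Measured so far
compound 1 `Cc1cc(NCc2ncccn2)n2nc(C)c(-c3ccccc3)c2n1`: 37900 nM
compound 2 `Cc1cc(NCc2ccccn2)n2ncc(-c3cccc(Cl)c3)c2n1`: < 5000 nM

Both values come from a physicochemical assay for solubility, read by HPLC, using the shake flask method, measured as kinetic solubility, with a stated time of 2 h, at pH 7.4; a lower number here means a less soluble compound, a higher number a more soluble compound. Compound 1 gives a number in this assay, 37900 nM. For compound 2 this assay reports only a limit, < 5000 nM, so its solubility is not known as a number. Compound 2 sits at the limit of < 5000 nM in this assay, at which 1 of the 2 values shown sits. Within the data shown here, no step between the two measured compounds is given, and the two differ at more than one place, so nothing is read from their pair.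

The open compound is compound 3 `Cc1cc(NCc2ccccn2)n2ncc(-c3ccncc3)c2n1`. It differs from compound 2 in one place: pyridin-4-yl in place of 3-chlorophenyl on an aromatic carbon. Among the measured compounds shown here, no measured step of this kind is available, so the size of the change can only be guessed. The expectation is that this assay will return a number for compound 3 rather than a limit, and that the step of an at least 4.0-fold higher number from compound 2 to compound 3 (0.60 log units; beyond the scatter) is expected to lie upward and beyond the usual scatter, though its size is uncertain. Compound 3 is therefore estimated at 20000 nM, with a range from 5000 nM to 80000 nM.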

Compound 3, solubility: 161000 nM
For compound 3 the middle estimate is 8.1-fold (0.91 log units) below the measured one, outside the stated range (above it).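

In this assay, pyridin-4-yl in place of 3-chlorophenyl on an aromatic carbon of the five-membered aromatic ring gives an at least 32-fold higher number from compound 2 to compound 3 (1.50 log units; beyond the scatter). Among these compounds, this is the first step between compounds that differ in one place, and it shows that the read-out at this position can move well beyond the scatter with a single change of group. The true size of the step stays open upward, because compound 2 rests on a limit of the assay and not on a number: the limit of < 5000 nM in this assay, at which 1 of the 3 values shown sits.

The change removes the chlorine and brings in the ring nitrogen together, so the compounds shown do not separate the two, and a single pair says nothing about how the step would carry over to other cores or to other groups on the amine side of the molecule. On these data alone, whether the placement of the ring nitrogen matters, or whether another kind of group at this carbon would give a similar step, remains open, and pyridin-3-yl, a morpholine or a phenyl ring bearing a carboxylic acid would each test that.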